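The source may report more compounds than this note shows. Statements on the series, on what has been measured and on what is new or still open speak of the compounds shown alone.

Of the compounds shown here, three on a shared core have been read so far in an ADME assay on microsomes from liver (Mus musculus) for metabolic stability, with a stated time of 10 min, tested at 0.5 uM (on this read-out higher numbers stand for a more stable compound and lower numbers for a less stable compound), as the measure of stability. Compound 1 (`C[C@@H](C(=O)NC1CCCCC1)[C@H]1CC[C@@H](c2ccnc3ccc(F)cc32)CC1`) shows < 1% as a limit of the assay, not a number. Compound 2 (`C[C@@H](c1nc2ccc(Cl)cc2[nH]1)[C@H]1CC[C@@H](c2ccnc3ccc(F)cc32)CC1`) gives 12% as a measured number. Compound 3 (`C[C@@H](NS(=O)(=O)c1ccc(Cl)cc1)[C@H]1CC[C@@H](c2ccnc3ccc(F)cc32)CC1`) shows < 1% as a limit too, so it stands at the limit of < 1% in this assay, at which 2 of the 3 values shown sit, and has no number of its own. Compound 4 (`C[C@@H](NC(=O)c1cccc(Cl)c1)[C@H]1CC[C@@H](c2ccnc3ccc(F)cc32)CC1`) differs from compound 3 by (3-chlorophenyl)carbonyl in place of (4-chlorophenyl)sulfonyl on an amine nitrogen with (3-chlorophenyl)carbonyl in place of (4-chlorophenyl)sulfonyl on an amine nitrogen. Going by the values given here, no measured pair isolates this change. The expected step is a number at least 1 percentage points higher from compound 3 to compound 4 (that floor lies within the scatter) and would be small and upward, within the usual scatter. Compound 4 is estimated at 2% with 0% to 10% as its expected range.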

Compound 4, percent of the compound remaining: 9%
Estimate against measurement, compound 4: 7 percentage points below, within the range that was stated.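

On an amine nitrogen, (3-chlorophenyl)carbonyl in place of (4-chlorophenyl)sulfonyl gives a number at least 8 percentage points higher from compound 3 to compound 4 (that floor lies within the scatter) in this assay. Compound 4 thus gives this position a measured number, 9%, where the earlier compound with this nitrogen offered none. Compound 3 remains a limit of the assay, not a number: the limit of < 1% in this assay, at which 2 of the 4 values shown sit.

The sulfonyl-to-carbonyl exchange and the shift of the chlorine come together here, so the compounds shown do not separate them. As far as these compounds go, how (4-chlorophenyl)carbonyl or an unsubstituted phenylcarbonyl on the same nitrogen would read remains open.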